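The source may report more compounds than this note shows. Statements on the series, on what has been measured and on what is new or still open speak of the compounds shown alone.

Working notes on the series. Compound 1 `O=[N+]([O-])c1cc(C(F)(F)F)cc([N+](=O)[O-])c1Oc1ccccc1/C=N/OCc1ccccc1Cl` gives 1170 nM in a functional assay on HepG2 cells (Homo sapiens) for antiproliferative activity, read by MTT assay, with a stated time of 48 h; a lower number here means a stronger inhibitor, a higher number a weaker inhibitor. Compound 3 `O=[N+]([O-])c1cc(C(F)(F)F)cc([N+](=O)[O-])c1Oc1ccc(Br)cc1/C=N/OCc1ccccc1Cl` gives 1240 nM in this assay, and the change from compound 1 is bromo in place of hydrogen on an aromatic carbon; the step is a 1.1-fold higher number from compound 1 to compound 3 (0.03 log units; within the scatter). Compound 2 `O=[N+]([O-])c1cc(C(F)(F)F)cc([N+](=O)[O-])c1Oc1ccc(Br)cc1/C=N\OCc1ccccc1` gives 1180 nM in this assay; how its core differs from that of compound 1 is not broken down here. The step of a 1.1-fold higher number from compound 2 to compound 3 (0.02 log units; within the scatter) is also small. Compound 4 `O=[N+]([O-])c1cc(C(F)(F)F)cc([N+](=O)[O-])c1Oc1c(Br)cc(Br)cc1/C=N\OCc1ccccc1` carries the change (bromo in place of hydrogen on an aromatic carbon), the same kind of change as from compound 1 to compound 3, though here the place is ortho to a large group and meta to a bromo group as well as meta to a large group. Because the step of a 1.1-fold higher number from compound 1 to compound 3 (0.03 log units; within the scatter) was within the scatter, the step from compound 2 to compound 4 is expected to be a 1.1-fold higher number from compound 2 to compound 4 (0.04 log units; within the scatter). Compound 4 is estimated at 1300 nM in this assay, with a range from 650 nM to 2600 nM.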

Compound 4, half-maximal inhibitory concentration: 1480 nM
Beside the measured number, compound 4's estimate is 1.1-fold (0.06 log units) below it; the measured number falls inside the stated range.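

Bromo in place of hydrogen on an aromatic carbon gives a 1.3-fold higher number from compound 2 to compound 4 (0.10 log units; within the scatter) in this assay. Set beside the earlier case, the change carries from one core to the other without a difference that can be told apart: the same change on two cores in this assay, a 1.1-fold higher number (0.03 log units; within the scatter) from compound 1 to compound 3 and a 1.3-fold higher number (0.10 log units; within the scatter) from compound 2 to compound 4, 1.2-fold (0.07 log units) apart, within the scatter of two such steps. For the compounds shown here, this shows only that on these two cores the step stays within the scatter; it does not show that bromo has a real effect on the number, and two pairs say nothing about cores beyond these compounds.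

The compounds shown leave open whether another group on this aromatic carbon, such as an amine, a carboxylic acid or a longer chain, would move the number beyond the scatter.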